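Amide Nitrogen Substituent Change in a Cytotoxicity Series

The source may hold more compounds than are shown below. What is called first, only, known or untested is meant among the compounds shown, and "the series" means these compounds.

Compound 1, `C=CC1=C(C(=O)Nc2ccc(C)cc2)C(c2ccc(F)cc2)OC1`, in a functional assay on HeLa cells (Homo sapiens) for cytotoxicity, read by MTT assay, with a stated time of 24 h (a higher number here means a weaker inhibitor, a lower number a stronger inhibitor), gives > 100000 nM, which is a limit of the assay and not a number.
Compound 2, `C=CC1=C(C(=O)NCCCCC)C(c2ccc(F)cc2)OC1`, in this assay gives > 100000 nM, again a limit of the assay.

Compound 2 thus stands at the upper boundary of what this assay reports, and both values shown so far sit at that same boundary: the limit of > 100000 nM in this assay, at which 2 of the 2 values shown sit. Among the compounds with values here, the only measured step, a step that the two limits leave unreadable from compound 1 to compound 2, is therefore unreadable, since a limit on each side hides its size and direction.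

Compound 3, `C=CC1=C(C(=O)Nc2cccc(C)c2)C(c2ccc(F)cc2)OC1`, has not yet been measured. It differs from compound 2 by 3-methylphenyl in place of pentyl on an amide-type nitrogen. Within the data shown here, the one measured step that touches this position, a step that the two limits leave unreadable from compound 1 to compound 2, gives no usable size, so no step beyond the scatter can be predicted for this assay in either direction, and the most that the data support is that compound 3 is expected to stay where compound 2 stands.

For compound 3 the estimated value in this assay is 150000 nM, with a range from 40000 nM to 600000 nM, an expected step that the limit leaves unreadable from compound 2 to compound 3, most likely reported only as a limit.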

Compound 3, half-maximal inhibitory concentration: "not active" (no number reported)
Compound 3 has no reported number here, and the estimate cannot be compared.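

Compound 3 is reported in this assay as "not active", without a number, so no step can be read between compound 2 and compound 3. The numerical record stays at the assay boundary: the limit of > 100000 nM in this assay, at which 2 of the 3 values shown sit.

The compounds shown leave open whether any group on the amide nitrogen of the shared core gives a measurable value in this assay.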